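Shifting One Hydroxyl Group on a Three-Armed Core

The compounds below may be only part of what the source reports. "The series", "measured", "known", "first", "only" and "open" are said of these compounds alone.

Compound 1 `Oc1ccc(-c2cc(-c3cccc(O)c3)nc(-c3ccccc3O)c2)cc1`: 4810 nM
Compound 2 `Oc1cccc(-c2cc(-c3ccccc3O)cc(-c3cccc(O)c3)n2)c1`: 4570 nM
Compound 3 `Oc1ccc(-c2cc(-c3cccc(O)c3)cc(-c3cccc(O)c3)n2)cc1`: 3920 nM

In a functional assay on T47D cells (Homo sapiens) for cytotoxicity, read by CCK-8 assay, with a stated time of 4 days (on this read-out lower numbers stand for stronger inhibition and higher numbers for weaker inhibition), compound 3 gives 3920 nM, the lowest of the three numbers, yet its gaps to compound 2 and to compound 1 are both within the scatter, so the three compounds cannot be told apart on these data. The step to compound 4 `Oc1ccc(-c2cc(-c3cccc(O)c3)cc(-c3ccccc3O)n2)cc1` is 2-hydroxyphenyl in place of 3-hydroxyphenyl on an aromatic carbon. Compound 1 with 4810 nM and compound 2 with 4570 nM each already carry a 2-hydroxyphenyl group on the shared core, and neither stands apart from compound 3, so this change shows no sign of mattering in this assay. The step from compound 3 to compound 4 is therefore expected to be a 1.1-fold higher number from compound 3 to compound 4 (0.06 log units; within the scatter), nothing beyond the scatter in either direction. Compound 4 is estimated at 4500 nM in this assay, with a range from 2500 nM to 8000 nM.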

Compound 4, half-maximal inhibitory concentration: 50000 nM
The estimate for compound 4 lay 11-fold (1.05 log units) below the measured number; the whole stated range lies below it.
By their numbers in this assay, from the lowest: compounds 3, 2 and 1 (each within the scatter of the next); then compound 4.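

In this assay, this change on an aromatic carbon next to the ring nitrogen is far from neutral: there is a 13-fold higher number from compound 3 to compound 4 (1.11 log units; beyond the scatter), which means much weaker inhibition. Among the compounds shown here, the two compounds contain the same atoms, so moving a single hydroxyl group around this one arm is enough to separate them clearly, whereas the earlier compounds could not be told apart. Nothing available here explains why this shift has such a large effect.

Going by these compounds, it remains open whether the hydroxyl group itself matters on this arm, which a plain phenyl or a methoxyphenyl group at the same place could test. It is also unknown whether an aminophenyl group, which has an amine in place of the hydroxyl, would keep the activity of compound 3 or fall away as compound 4 does.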